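This account rests on a few compounds, and the source may have more. Where it says the series, first, only, none or still open, it means among the compounds named here.

All three measured compounds were tested in an ADME assay on MT4 cells (Homo sapiens) for cytotoxicity, read by MTT assay; a lower number here means that less compound is tolerated, a higher number that more compound is tolerated:

compound 1, `S=C(Nc1cccc(Cl)c1)OCCc1ccccn1`, gives 47000 nM
compound 2, `O=[N+]([O-])c1cccc(NC(=S)OCCc2ccccn2)c1`, gives 100000 nM
compound 3, `S=C(Nc1ccc(Cl)cc1)OCCc1ccccc1`, gives only a limit, > 100000 nM

The value of compound 3 is a limit of this assay and not a number; it sits at the limit of > 100000 nM in this assay, at which 1 of the 3 values shown sits.

Compound 1 and compound 2 differ by nitro in place of chloro on an aromatic carbon. That change gave a 2.1-fold higher number from compound 1 to compound 2 (0.33 log units; beyond the scatter) in this assay.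

Compound 4, `O=[N+]([O-])c1ccc(NC(=S)OCCc2ccccc2)cc1`, has not yet been measured. It differs from compound 3 by nitro in place of chloro on an aromatic carbon. Going by the values given here, this is the same kind of change as the one from compound 1 to compound 2, but not the same: there the place was meta to a large group, here it is para to a large group. How the core of compound 3 differs from the core of compound 1 is not broken down here.

For compound 3 the measurement already stops at a limit, > 100000 nM. Among the compounds with values here, the only measured step of this kind pushed the number up, and so compound 4 is expected to sit at or beyond the same limit rather than below it. The step expected from compound 3 to compound 4 in this assay is therefore a step that the limit leaves unreadable from compound 3 to compound 4. For compound 4 the estimate is 130000 nM, between 60000 nM and 300000 nM.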

Compound 4, half-maximal cytotoxic concentration: > 100000 nM
Compound 4: a limit, no number; the forecaster's own chance of this, stated with the estimate: 75%; the middle value is on the limit's open side.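

In this assay compound 4 gives > 100000 nM as a limit and not a number. Going by these compounds alone, compound 3 stands at the same limit, so no step from compound 3 to compound 4 can be read: the limit of > 100000 nM in this assay, at which 2 of the 4 values shown sit.

The compounds shown leave open how large the change from chloro to nitro is here, and whether it runs the same way as between compound 1 and compound 2.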